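The source may hold more compounds than are shown below. What is called first, only, known or untested is meant among the compounds shown, and "the series" means these compounds.

In a functional assay on HCT-116 cells (Homo sapiens), read by MTT assay, with a stated time of 72 h (a lower number here means a stronger inhibitor, a higher number a weaker inhibitor), compound 1 (`CNc1ncnc2c1c(-c1ccco1)cn2[C@@H]1O[C@H](CO)[C@@H](O)[C@H]1O`) gives 440 nM. Compound 2 (`CNc1ncnc2c1c(-c1ccoc1)cn2[C@@H]1O[C@H](CO)[C@@H](O)[C@H]1O`) gives > 20000 nM, which is a limit of the assay. Compound 3 (`CNc1ncnc2c1c(-c1cccs1)cn2[C@@H]1O[C@H](CO)[C@@H](O)[C@H]1O`) gives > 20000 nM, also a limit and not a number. Two large measured steps lead away from compound 1: an at least 45-fold higher number from compound 1 to compound 2 (1.65 log units; beyond the scatter) and an at least 45-fold higher number from compound 1 to compound 3 (1.65 log units; beyond the scatter). Between the two limits lies a step that the two limits leave unreadable from compound 2 to compound 3. Compound 4 (`CNc1ncnc2c1c(-c1ccccc1)cn2[C@@H]1O[C@H](CO)[C@@H](O)[C@H]1O`) has phenyl in place of thiophen-2-yl on an aromatic carbon. Compound 1 alone has a measured number, and compound 3 already sits far from it in an at least 45-fold higher number from compound 1 to compound 3 (1.65 log units; beyond the scatter), so no recovery is expected in this assay. The expected change is a number no higher from compound 3 to compound 4 (the limit leaves the size open), with no step beyond the scatter foreseen. For compound 4 the estimate is 20000 nM, with an expected range from 5000 nM to 40000 nM.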

Compound 4, half-maximal inhibitory concentration: > 100000 nM
Compound 4 was reported as a limit; the forecaster's own chance of this, stated with the estimate: 80%; middle value at least 5.0-fold (0.69 log units) away from the limit.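

Phenyl on this aromatic carbon brings an at least 220-fold higher number from compound 1 to compound 4 (2.35 log units; beyond the scatter) in this assay and extends the loss seen with the five-membered rings to a six-membered aromatic ring of carbon only. Of the four groups shown at this position, furan-2-yl alone gives a measured number, while compound 2, compound 3 and compound 4 all stand at limits. The steps to compound 4 from compound 2 and from compound 3 cannot be read. As far as these compounds go, it remains open whether a methyl or hydroxymethyl group on the furan-2-yl ring of compound 1 would keep a measured number. From the compounds shown here alone, what a pyridin-2-yl or oxazol-2-yl group would give on this carbon also stays open.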